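Trifluoromethyl in Place of Fluoro on Compound 3

The source may report more compounds than this note shows. Statements on the series, on what has been measured and on what is new or still open speak of the compounds shown alone.

Three compounds share one core and were tested in an assay on CHO cells for displacement of a labelled ligand from melanin-concentrating hormone receptor 1 (Homo sapiens), read by scintillation counting, with a stated time of 1 h; a higher number here means a weaker inhibitor, a lower number a stronger inhibitor. Compound 1 `Cc1nc2ccc(NC(=O)COc3ccc(OC(F)(F)F)cc3)cn2c1C` gives 3.8 nM, and compound 2 `Cc1c(C2CC2)nc2ccc(NC(=O)COc3ccc(OC(F)(F)F)cc3)cn12` gives 3 nM. Among the compounds with values here, the only single-point step among them, a 1.3-fold lower number from compound 1 to compound 2 (0.10 log units; within the scatter), lies within the scatter. Compound 3 `Cc1c(C2CC2)nc2ccc(-n3ccc(OCc4ccc(F)cc4)cc3=O)cn12` gives 47 nM, the highest number of the three; its gaps to compound 1 and to compound 2 both lie beyond the scatter, so on these numbers compound 3 is the weakest inhibitor of the set.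

Compound 4 `Cc1c(C2CC2)nc2ccc(-n3ccc(OCc4ccc(C(F)(F)F)cc4)cc3=O)cn12` differs from compound 3 in one place: trifluoromethyl in place of fluoro on an aromatic carbon. Within the data shown here, no measured step bears directly on this change; the one step that is known, from compound 1 to compound 2, concerns a different position on the core and was within the scatter. With nothing in the data speaking for a shift in either direction, the expected step in this assay is none beyond the scatter. Compound 4 is therefore expected to give about 40 nM, with a range from 15 nM to 120 nM. The step this estimate means, a 1.2-fold lower number from compound 3 to compound 4 (0.07 log units; within the scatter), is expected to stay within the usual scatter of repeated measurements.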

Compound 4, half-maximal inhibitory concentration: 72 nM
Estimate against measurement, compound 4: 1.8-fold (0.26 log units) below, within the range that was stated.
By their numbers in this assay, from the lowest: compounds 2 and 1 (each within the scatter of the next); then compounds 3 and 4 (each within the scatter of the next).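

In this assay, within the data shown here, the change from 4-fluorophenyl to 4-(trifluoromethyl)phenyl gives a 1.5-fold higher number from compound 3 to compound 4 (0.19 log units; within the scatter) and so provides the first reading at this place, on an aromatic carbon of the six-membered ring and para to a large group. The earlier step concerned a different position on the shared core, whereas this one shows that trifluoromethyl, with 4 heavy atoms, can stand where fluoro, with 1 heavy atom, stood without a shift beyond the scatter in this read-out. Nothing available explains this outcome or indicates how either group acts at this place.

What the compounds shown leave open is whether this place responds in the same way to groups of a different kind, such as an amine, a carboxylic acid, a nitrile or a longer alkyl chain, or to plain hydrogen in place of fluoro. They also leave open whether the same exchange would read alike with methyl in place of cyclopropyl on the shared core, since a single step at this place cannot establish a general trend.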